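Compound 2 to compound 4: nitro replaced by hydroxy

The compounds below may be only part of what the source reports. "The series", "measured", "known", "first", "only" and "open" are said of these compounds alone.

In an in vitro assay on cells for inhibition of Amine oxidase [flavin-containing] B (Homo sapiens), read by Amplex Red, with a stated time of 15 min (on this read-out lower numbers stand for stronger inhibition and higher numbers for weaker inhibition), compound 2 `O=C(/C=C(O)/C=C/c1ccc([N+](=O)[O-])cc1)c1ccccc1O` gives 2670 nM, the highest of the three numbers; compound 1 `COc1ccc(/C=C/C=C/C(=O)c2ccccc2O)cc1` gives 1810 nM, within the scatter of compound 2, while compound 3 `O=C(/C=C/C=C/c1ccccc1)c1ccccc1O` gives 106 nM, far below both. Compound 4 `O=C(/C=C(O)/C=C/c1ccc(O)cc1)c1ccccc1O` differs from compound 2 by hydroxy in place of nitro on an aromatic carbon. Going by the values given here, no measured step exchanges these two groups. Among the compounds with values here, the one step at the same place, a 17-fold lower number from compound 1 to compound 3 (1.23 log units; beyond the scatter), shows that taking a group off this ring carbon lowers the number sharply, but compound 4 keeps a substituent there, so only part of that gain is expected. The step from compound 2 to compound 4 is therefore expected to be moderate, a 2.7-fold lower number from compound 2 to compound 4 (0.43 log units; beyond the scatter). Compound 4 is expected at 1000 nM, with a range of 300 nM to 3500 nM.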

Compound 4, half-maximal inhibitory concentration: 26.5 nM
The estimate for compound 4 lay 38-fold (1.58 log units) above the measured number; measured number below the stated range.
By their numbers in this assay, from the lowest: compound 4; then compound 3; then compounds 1 and 2 (each within the scatter of the next).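

In this assay the ring carbon para to a large group proves highly sensitive to which substituent it carries, with a 100-fold lower number from compound 2 to compound 4 (2.00 log units; beyond the scatter) when hydroxy takes the place of nitro. The earlier step, a 17-fold lower number from compound 1 to compound 3 (1.23 log units; beyond the scatter), came from removing a methoxy, whereas this one shows that a low number does not require an unsubstituted carbon here. Nothing on hand explains the size of this step. Open, from the compounds shown here alone, is how hydrogen, methoxy or an amine at this carbon would read on the core of compound 4. Also open, going by these compounds, is whether the low number depends on hydroxy itself or mainly on the absence of nitro.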